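Swapping the styryl arm for cyclopentyl on compound 3

The source may report more compounds than this note shows. Statements on the series, on what has been measured and on what is new or still open speak of the compounds shown alone.

Compound 1 `O=c1cc(NC2CCCCC2)cc(/C=C/c2ccccc2)o1`: 1.23 uM
Compound 2 `O=c1cc(NC2CC2)cc(-c2ccccc2)o1`: > 30 uM
Compound 3 `COc1ccc(Nc2cc(/C=C/c3ccccc3)oc(=O)c2)cc1`: 0.11 uM

All three results come from a functional assay on DU-145 cells (Homo sapiens) for cytotoxicity, read by MTT assay, with a stated time of 72 h; on this read-out lower numbers stand for an effect already at smaller amounts and higher numbers for an effect only at larger amounts of compound. Compound 3 holds the lowest of the two true numbers, at 0.11 uM. The value of compound 2 is a limit and not a number. Among the measured compounds shown here, the only measured step is an 11-fold lower number from compound 1 to compound 3 (1.05 log units; beyond the scatter). That change sits on the nitrogen, and the 2-phenylethenyl stays in place on both sides of it, so it does not directly address the next change.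

Compound 4 `COc1ccc(Nc2cc(C3CCCC3)oc(=O)c2)cc1` differs from compound 3 in one place: cyclopentyl in place of 2-phenylethenyl on an aromatic carbon. The new group sits on an aromatic carbon, next to the ring oxygen. For the measured compounds named here, no measured step changes this group alone. Going by the values given here, compound 2 is the only measured compound without the 2-phenylethenyl, and its > 30 uM is a limit, but it also differs on the nitrogen. This is weak evidence, yet it points towards a higher number in this assay, beyond the scatter. The expected change is a 45-fold higher number from compound 3 to compound 4 (1.66 log units; beyond the scatter). For compound 4 the estimated value is 5 uM, with an expected range from 0.8 uM to 30 uM.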

Compound 4, concentration for half-maximal effect: 5.42 uM
For compound 4 the middle estimate is 1.1-fold (0.04 log units) below the measured one; low and high end bracket the measured number.
By their numbers in this assay, from the lowest: compound 3; then compound 1; then compound 4. At a limit, above all of these: compound 2.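

Among the compounds shown here, this is the first measured step that changes only the group on this aromatic carbon, with the 4-methoxyphenyl on the nitrogen left in place: in this assay, cyclopentyl in place of 2-phenylethenyl gives a 49-fold higher number from compound 3 to compound 4 (1.69 log units; beyond the scatter). What sits on this carbon, next to the ring oxygen, therefore counts heavily in this series, and the earlier comparison, made on the nitrogen alone, could not show that. The effect is not lost entirely, though, as compound 4 still gives a true number of 5.42 uM, so a saturated ring of carbon at this place leaves measurable cytotoxicity in these cells.

The compounds shown cannot tell whether the aromatic ring or the double bond of the 2-phenylethenyl matters more, and a 2-phenylethyl chain, which keeps the ring but has no double bond outside it, would separate the two on this same core. Compound 2 differs in both places and offers only a limit, not a number, so it cannot settle this question: the limit of > 30 uM in this assay, at which 1 of the 4 values shown sits.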